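Changing the Aromatic Group on the Ring Nitrogen

The compounds below may be only part of what the source reports. "The series", "measured", "known", "first", "only" and "open" are said of these compounds alone.

Three compounds share one core and differ only in the aromatic group carried by an amine nitrogen in a ring. In an assay on HEK293 cells for inhibition of Voltage-dependent T-type calcium channel subunit alpha-1G (Homo sapiens), read by fluorescence, tested at 10 uM (on this read-out lower numbers stand for less inhibition and higher numbers for more inhibition at the one concentration tested (going by the name of the read-out)), compound 1 `CCCc1nc(-c2ccccc2)c(CNCCCN2CCN(c3cccc(C(F)(F)F)c3)CC2)o1` gives 51.6%. Compound 2 `CCCc1nc(-c2ccccc2)c(CNCCCN2CCN(c3cccc(C)c3C)CC2)o1` gives 55.2% in this assay, and compound 3 `CCCc1nc(-c2ccccc2)c(CNCCCN2CCN(c3ccc(C)cc3)CC2)o1` gives 53.9%. The step of a number 3.6 percentage points higher from compound 1 to compound 2 (within the scatter) and the step of a number 2.3 percentage points higher from compound 1 to compound 3 (within the scatter) show that exchanging one aromatic group for another here leaves the read-out essentially unchanged, and the same holds for a number 1.3 percentage points lower from compound 2 to compound 3 (within the scatter). On these numbers compound 3 stands second highest of the three, nearest to compound 2 and furthest from compound 1, although all three values sit within the scatter of one another.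

Compound 4 `CCCc1nc(-c2ccccc2)c(CNCCCN2CCN(c3ccccc3F)CC2)o1` has not yet been measured. It differs from compound 3 in one place: 2-fluorophenyl in place of 4-methylphenyl on an amine nitrogen in a ring. All three measured steps bear on this change. Each of them swaps the aromatic group on the same amine nitrogen in a ring, and each stayed within the scatter. A 2-fluorophenyl group has not been tested in this series, so the expectation rests only on those steps. Compound 4 is therefore expected to show no step beyond the scatter, a number 0.9 percentage points lower from compound 3 to compound 4 (within the scatter). The estimated value for compound 4 in this assay is 53%, with a range from 40% to 66%.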

Compound 4, a percentage reported as inhibition, at one concentration (the size of the read-out at that concentration, not a potency): 54.4%
Beside the measured number, compound 4's estimate is 1.4 percentage points below it; the measured number falls inside the stated range.
By their numbers in this assay, from the lowest: compounds 1, 3, 4 and 2 (each within the scatter of the next).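

In this assay, the new steps are a number 0.5 percentage points higher from compound 3 to compound 4 (within the scatter), a number 0.8 percentage points lower from compound 2 to compound 4 (within the scatter) and a number 2.8 percentage points higher from compound 1 to compound 4 (within the scatter). The 2-fluorophenyl group therefore joins the earlier aromatic groups on this amine nitrogen in a ring without a single step beyond the scatter, so a ring fluorine can now be added to the methyl and trifluoromethyl groups as a change that leaves this read-out flat, and the four compounds cannot be ranked against one another. No measured information is available to explain why these swaps make so little difference.

Among the compounds shown here, every group at this position so far is a phenyl ring bearing only fluorine, methyl or trifluoromethyl, so it remains open whether a group of a different kind on that ring, such as a carboxylic acid or an amine, would produce a step beyond the scatter. The rest of the molecule is the same in all four compounds, which leaves open what a longer chain between the two nitrogens of the shared core would do, and a single tested concentration gives no potency for any of them.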